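The source may report more compounds than this note shows. Statements on the series, on what has been measured and on what is new or still open speak of the compounds shown alone.

Compound 1 `COc1ccc(NC(=O)c2cncc(N3CC4CC(C3)N4)c2)cc1OC` gives 516 nM in an assay on cells for displacement of a labelled ligand from Neuronal acetylcholine receptor; alpha3/beta4 (Homo sapiens); on this read-out higher numbers stand for weaker inhibition and lower numbers for stronger inhibition.
Compound 2 `O=C(Nc1ccc(F)cc1F)c1cncc(N2CC3CC(C2)N3)c1` gives 50 nM in this assay.

Within the data shown here, of these two numbers, compound 2 holds the lower one, and compound 1 sits beyond the usual scatter above it; with only one pair in hand, nothing further can be drawn from that gap. The next compound, compound 3 `CCc1cccc(NC(=O)c2cncc(N3CC4CC(C3)N4)c2)c1`, keeps the shared core and the amide of compound 2 and alters only the aryl group: 3-ethylphenyl in place of 2,4-difluorophenyl on an amide-type nitrogen. Among the measured compounds shown here, no measured pair shows this particular exchange, so its effect cannot be read from the compounds at hand. What the two measured compounds do show is that a change of the group on the amide-type nitrogen alone separates compound 2 at 50 nM from compound 1 at 516 nM in this assay. The step is expected to be a 2.6-fold higher number from compound 2 to compound 3 (0.41 log units; beyond the scatter), a modest move toward weaker inhibition that may still lie inside the scatter. Compound 3 is estimated to give 130 nM in this assay, with a range from 40 nM to 450 nM.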

Compound 3, inhibition constant: 306 nM
Beside the measured number, compound 3's estimate is 2.4-fold (0.37 log units) below it, and the stated range covers the measured number.
By their numbers in this assay, from the lowest: compound 2; then compounds 3 and 1 (each within the scatter of the next).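

Among these compounds, exchanging the 2,4-difluorophenyl for 3-ethylphenyl on the amide-type nitrogen gives a 6.1-fold higher number from compound 2 to compound 3 (0.79 log units; beyond the scatter) in this assay, the first direct reading of a single change at this place. The two groups match in heavy-atom count, in their single six-membered aromatic ring of carbon only, and in their hydrogen-bond donor and acceptor counts, and they differ in their substituents, so those shared counts alone do not set the number in this series. Compound 3 and compound 1 lie within the scatter of each other despite their different aryl groups, leaving compound 2 as the only one of the three clearly apart from the others, and nothing at hand accounts for that separation.

The compounds shown leave open whether the gap follows from the loss of the fluorines or from the arrival of the ethyl group, since both happen in the same step. A phenyl group bearing a single fluorine, a chlorine or a methyl group, or a pyridine ring in place of the phenyl ring, could help to separate those two readings.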